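Amine variation on a shared chlorinated biaryl core

The compounds below may be only part of what the source reports. "The series", "measured", "known", "first", "only" and "open" are said of these compounds alone.

Measured so far: compound 1 `COc1ccccc1-c1cc(C2CCNC2)ccc1Cl` gives 3.4 nM in an assay on isolated protein for binding affinity to 5-hydroxytryptamine receptor 1D (Homo sapiens); on this read-out higher numbers stand for weaker inhibition and lower numbers for stronger inhibition; compound 2 `CNCc1ccc(Cl)c(-c2ccccc2OC)c1` gives 1200 nM; compound 3 `CCCCNCc1ccc(Cl)c(-c2ccccc2OC)c1` gives 2000 nM.

Compound 3 stands highest of the three numbers. The step of a 1.7-fold higher number from compound 2 to compound 3 (0.22 log units; within the scatter) lies within the scatter, whereas a 350-fold higher number from compound 1 to compound 2 (2.55 log units; beyond the scatter) and a 590-fold higher number from compound 1 to compound 3 (2.77 log units; beyond the scatter) are large and both concern replacement of pyrrolidin-3-yl.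

Compound 4 `CCN(CC)Cc1ccc(Cl)c(-c2ccccc2OC)c1` differs from compound 3 by diethylamino in place of butylamino on a saturated chain carbon bound to an aromatic carbon. Going by the values given here, the only measured step at this position is a 1.7-fold higher number from compound 2 to compound 3 (0.22 log units; within the scatter), which is small. The large steps involve a different group and do not bear directly. A step in this assay of no more than the scatter is therefore expected, a 1.3-fold higher number from compound 3 to compound 4 (0.10 log units; within the scatter). Compound 4 is estimated at 2500 nM, range 900 nM to 7000 nM.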

Compound 4, inhibition constant: > 10000 nM
Compound 4: only a limit was reported; the forecaster's own chance of this, stated with the estimate: 5%; middle value at least 4.0-fold (0.60 log units) from the limit.
By their numbers in this assay, from the lowest: compound 1; then compounds 2 and 3 (each within the scatter of the next). At a limit, above all of these: compound 4.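

In this assay compound 4 is reported only as a limit, not a number: the limit of > 10000 nM in this assay, at which 1 of the 4 values shown sits. Lengthening the chain on the amine had moved nothing beyond the scatter, yet rearranging the same atoms into diethylamino, which carries no hydrogen-bond donor where butylamino carries one, gives an at least 5.0-fold higher number from compound 3 to compound 4 (0.69 log units; beyond the scatter), along with an at least 8.3-fold higher number from compound 2 to compound 4 (0.92 log units; beyond the scatter). The gap to the pyrrolidin-3-yl compound widens to an at least 2900-fold higher number from compound 1 to compound 4 (3.46 log units; beyond the scatter).

The compounds shown cannot separate the loss of the donor from the change in chain shape. A dimethylamino or isopropylamino group on the same saturated chain carbon would bear on that question.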